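Fluoro to methyl on the sulfonyl-bearing phenyl ring

The source may report more compounds than this note shows. Statements on the series, on what has been measured and on what is new or still open speak of the compounds shown alone.

Measured so far:
compound 1 `CN1CCN(c2ccc3[nH]nc(S(=O)(=O)c4ccc(F)cc4)c3c2)CC1` — 5.2 nM
compound 2 `O=S(=O)(c1cccc2ccccc12)c1n[nH]c2cccc(N3CCNCC3)c12` — 48 nM

In an assay on HeLa cells for displacement of a labelled ligand from 5-hydroxytryptamine receptor 6 (Homo sapiens) (a higher number here means a weaker inhibitor, a lower number a stronger inhibitor), compound 1 gives the lowest of the two numbers recorded; the nearest is compound 2, whose value lies beyond the scatter above it. Among the measured compounds shown here, compound 2 is not a single-change partner of compound 1, so their two values show only that compound 1 is the stronger of the pair.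

Compound 3 `Cc1ccc(S(=O)(=O)c2n[nH]c3ccc(N4CCN(C)CC4)cc23)cc1` is still to be measured in this assay. It differs from compound 1 as follows: methyl in place of fluoro on an aromatic carbon. The exchange sits on an aromatic carbon of a six-membered aromatic ring of carbon only, para to a large group, and leaves donor and acceptor counts unchanged.

For the measured compounds named here, no single-change step is available to calibrate such an exchange. The expected step from compound 1 to compound 3 is a 1.3-fold higher number from compound 1 to compound 3 (0.10 log units; within the scatter), that is, no change beyond the scatter in either direction. Compound 3 is therefore estimated at 6.5 nM, with a range from 2.2 nM to 19 nM.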

Compound 3, inhibition constant: 4.9 nM
The estimate for compound 3 lay 1.3-fold (0.12 log units) above the measured number, within the range that was stated.
By their numbers in this assay, from the lowest: compounds 3 and 1 (each within the scatter of the next); then compound 2.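

In this assay, among the compounds shown here, 4-fluorophenyl to 4-methylphenyl gives a 1.1-fold lower number from compound 1 to compound 3 (0.03 log units; within the scatter) and is the first single-change step. At this place, on an aromatic carbon para to a large group, the two substituents cannot be told apart in this assay. For the compounds shown here, the step covers only this exchange of one heavy atom for one heavy atom, with donor and acceptor counts unchanged, and no measurement at hand accounts for the match.

As far as these compounds go, whether the same place accepts a larger or differently functionalised group, such as methoxy, a carboxylic acid, an amine or a longer alkyl chain, remains open. Compound 2 differs from compound 1 in more than one place, so it does not settle this question.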